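The source may report more compounds than this note shows. Statements on the series, on what has been measured and on what is new or still open speak of the compounds shown alone.

Compound 1 `Cn1c(Cc2nn(C)c(=O)c3ccccc23)nnc1SCC(=O)Nc1ccc(Cl)cc1Cl` and compound 2 `Cn1c(Cc2nn(C)c(=O)c3ccccc23)nnc1SCCCCCCCC(=O)Nc1ccc(Cl)cc1Cl` are close relatives; the difference between the two cores is not broken down here. In an assay on 32D cells for inhibition of interleukin-15 (Mus musculus), read by resazurin assay, with stated times of 30 min and 2.5 days, in the presence of a further agent that is not named here (a higher number here means a weaker inhibitor, a lower number a stronger inhibitor), compound 1 gives 22500 nM. In this assay compound 2 gives 2200 nM, the lower of the two numbers, and compound 1 sits above it by a gap beyond the usual scatter. Compound 3 `CCOC(CCn1c(Cc2nn(C)c(=O)c3ccccc23)nnc1SCC(=O)Nc1ccc(Cl)cc1Cl)OCC` carries the change under study: 2,2-diethoxyethyl in place of hydrogen on a saturated chain carbon bound to an aromatic nitrogen. In this assay compound 3 reaches only > 30000 nM, which is a limit of the measurement and not a number. That change made a step of an at least 1.3-fold higher number from compound 1 to compound 3 (0.12 log units; that floor lies within the scatter); its true size is not fixed, because of the limit of > 30000 nM in this assay, at which 1 of the 3 values shown sits. Compound 4 `CCOC(CCn1c(Cc2nn(C)c(=O)c3ccccc23)nnc1SCCCCCCCC(=O)Nc1ccc(Cl)cc1Cl)OCC` carries the same change on the core of compound 2: 2,2-diethoxyethyl in place of hydrogen on a saturated chain carbon bound to an aromatic nitrogen. The place is the same in both cases, so the change is taken as the same. A weakening step of a 3.0-fold higher number from compound 2 to compound 4 (0.47 log units; beyond the scatter) from compound 2 to compound 4 is expected, resting on compound 3 reaching only the limit > 30000 nM after the same change. For compound 4 the estimated number is 6500 nM, expected between 2500 nM and 25000 nM.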

Compound 4, half-maximal inhibitory concentration: 12100 nM
Compound 4: middle estimate off by 1.9-fold (0.27 log units), on the low side, and the stated range covers the measured number.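

In this assay, the change to 2,2-diethoxyethyl gives a 5.5-fold higher number from compound 2 to compound 4 (0.74 log units; beyond the scatter), so on this core it clearly weakens inhibition by a size that can be read. On the other core the size stays unfixed, since compound 3 gives > 30000 nM, which is a limit of the assay and not a number. The series therefore offers one readable step, and that step does not show that the change costs the same on both cores: the same change on two cores in this assay, an at least 1.3-fold higher number (0.12 log units; that floor lies within the scatter) from compound 1 to compound 3 and a 5.5-fold higher number (0.74 log units; beyond the scatter) from compound 2 to compound 4; the limit leaves it open whether they differ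

The compounds shown leave open whether the weakening comes from the added length of the chain or from its two ethoxy groups, and a simple amine or a carboxylic acid at the end of a chain in the same place, on a saturated chain carbon bound to an aromatic nitrogen, could help separate the two. They also leave open whether the step would hold on a core whose sulfur-linked chain has another length.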